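The source may report more compounds than this note shows. Statements on the series, on what has been measured and on what is new or still open speak of the compounds shown alone.

Compound 1 `Cc1cc(=O)c2c(O)cc(OC/C=C/c3ccccc3)c([C@H]3CCN(C)C[C@H]3O)c2o1` gives 9%
Compound 2 `Cc1cc(=O)c2c(O)c(CN3CCCC3C(=O)O)c(O)c([C@H]3CCN(C)C[C@H]3O)c2o1` gives 30%
Compound 3 `Cc1oc2c([C@H]3CCN(C)C[C@H]3O)c(O)cc(O)c2c(=O)c1C(O)c1ccc(Cl)cc1` gives 3%

In a functional assay on Caco-2 cells (Homo sapiens) for inhibition, read by MTT assay, with a stated time of 48 h, tested at 10 uM (a lower number here means less inhibition of growth, a higher number more inhibition of growth at the concentration tested), compound 3 reads 3%, within the scatter of compound 1 and beyond the scatter under compound 2. Compound 4 `Cc1oc2c([C@H]3CCN(C)C[C@H]3O)c(O)cc(O)c2c(=O)c1C(O)c1c(F)cccc1Cl` differs from compound 3 in one place: 2-chloro-6-fluorophenyl in place of 4-chlorophenyl on a saturated chain carbon bound to an aromatic carbon and an oxygen on a saturated carbon, with 2-chloro-6-fluorophenyl in place of 4-chlorophenyl on a saturated chain carbon bound to an aromatic carbon and an oxygen on a saturated carbon. Within the data shown here, no measured pair shows what such a change does, so no step beyond the scatter is expected in this assay, in either direction. The expected change is small, an estimated a number 3 percentage points higher from compound 3 to compound 4 (within the scatter), and stays within the scatter. Compound 4 is estimated at 6%, with an expected range from 0% to 18%.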

Compound 4, percent growth inhibition at one concentration: 18%
For compound 4 the middle estimate is 12 percentage points below the measured one; measured number inside the range.
By their numbers in this assay, from the lowest: compounds 3, 1 and 4 (each within the scatter of the next, the first and the last beyond it); then compound 2.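

At the saturated chain carbon bound to an aromatic carbon and an oxygen on a saturated carbon, the aryl group proves able to shift the reading: in this assay, 2-chloro-6-fluorophenyl in place of 4-chlorophenyl gives a number 15 percentage points higher from compound 3 to compound 4 (beyond the scatter) as a modest step. Among these compounds, this is the first change in a single place seen. Nothing available bears on what lies behind this step.

The compounds shown do not separate the added fluorine from the moved chlorine, which a 2-chlorophenyl or 2-fluorophenyl group at this carbon would do. Also open, from the compounds shown here alone, is how a pyridine ring or an amine would read there in place of the phenyl ring.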